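Sec-butyl for cyclohexyl on the amine nitrogen

A few compounds are considered here, and "the series" means these few. Any claim that something is new, unique, unknown or untested is made for them only; others in the source may bear on it.

Compound 1 `COc1cc(/C=C/C(=O)/C=C(/C=C/c2ccc(OC(C)=O)c(OC)c2)NC2CCCCC2)ccc1OC(C)=O`: > 25000 nM (a limit)
Compound 2 `CC(=O)Oc1ccc(/C=C/C(=O)/C=C(/C=C/c2ccc(OC(C)=O)cc2)NCC(C)C)cc1`: 13700 nM
Compound 3 `COc1cc(/C=C/C(=O)/C=C(/C=C/c2ccc(O)c(OC)c2)NCC(C)C)ccc1O`: 24500 nM

All three were read in a functional assay on HT-29 cells (Homo sapiens) for inhibition, read by MTT assay, with a stated time of 72 h; a lower number here means a stronger inhibitor, a higher number a weaker inhibitor. Compound 1 stands at the limit of > 25000 nM in this assay, at which 1 of the 3 values shown sits, and that entry is a limit, not a number. Compound 4 `CCC(C)NC(=C\C(=O)/C=C/c1ccc(OC(C)=O)c(OC)c1)/C=C/c1ccc(OC(C)=O)c(OC)c1` is still unmeasured. It keeps the core of compound 1 and changes one group: sec-butyl in place of cyclohexyl on an amine nitrogen. Going by the values given here, no measured pair isolates this change. Compound 2 at 13700 nM and compound 3 at 24500 nM carry no ring on that nitrogen and both give numbers, so a modest move toward a lower number is expected. The expected step of an at least 1.3-fold lower number from compound 1 to compound 4 (0.14 log units; that floor lies within the scatter) is small. Compound 4 is estimated at 18000 nM, with an expected range of 9000 nM to 32000 nM.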

Compound 4, half-maximal inhibitory concentration: > 25000 nM
Compound 4 was reported as a limit; the forecaster's own chance of this, stated with the estimate: 30%; at least 1.3-fold (0.14 log units) between middle value and limit.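

Compound 1 and compound 4 are both limits, so no step can be read between them: the limit of > 25000 nM in this assay, at which 2 of the 4 values shown sit.

The compounds shown leave open whether sec-butyl in place of cyclohexyl on an amine nitrogen changes the read-out at all.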